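Tolerability of Three Aryl Amides in Human Monocytic Cells

The compounds below may be only part of what the source reports. "The series", "measured", "known", "first", "only" and "open" are said of these compounds alone.

Measured compounds:
- compound 1 `COc1ccc(-c2cnc(NC(=O)c3cccnc3)n2C)cc1`: > 100000 nM
- compound 2 `Cn1c(-c2cccc(C#N)c2)cnc1NC(=O)c1ncc[nH]1`: > 50000 nM
- compound 3 `Cn1c(-c2ccc(F)cc2)cnc1NC(=O)c1ccc(F)cc1`: > 100000 nM

The three compounds share a core and were examined in a toxicity assay on THP-1 cells (Homo sapiens) for inhibition; a higher number here means that more compound is tolerated, a lower number that less compound is tolerated. Compound 1 gives > 100000 nM there, which is a limit of the assay rather than a number. Compound 2 gives > 50000 nM, also a limit. Compound 3 gives > 100000 nM, again a limit. Thus every value so far sits at a limit: two of the three at the limit of > 100000 nM in this assay, at which 2 of the 3 values shown sit, and one at the limit of > 50000 nM in this assay, at which 1 of the 3 values shown sits. None of the compounds has shown a measurable half-maximal cytotoxic concentration, and no difference between any two of them can be read from these values.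

Compound 4 `COc1ccc(-c2cnc(NC(=O)c3cccc(C#N)c3)n2C)cc1` has not yet been measured. It differs from compound 1 by 3-cyanophenyl in place of pyridin-3-yl on a carbonyl carbon. Compound 2 also carries a 3-cyanophenyl group and sits at a limit, so no step beyond the scatter is expected in this assay. Compound 4 is therefore expected to give about 100000 nM, in the range 50000 nM to 200000 nM, most likely reported as a limit again. The step from compound 1 to compound 4 that this estimate means is a number no higher from compound 1 to compound 4 (the limit leaves the size open), which is expected to be essentially nil.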

Compound 4, half-maximal cytotoxic concentration: > 100000 nM
Compound 4: only a limit was reported; the forecaster's own chance of this, stated with the estimate: 80%; the middle value sits exactly at the limit.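

In this assay, going by these compounds alone, compound 4 gives > 100000 nM, which is a limit of the assay, as is the value of compound 1, so no step between compound 1 and compound 4 can be read. The compounds shown leave open whether any of them has a measurable half-maximal cytotoxic concentration.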